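From Ethylsulfanyl to Methylsulfanyl in Compound 4

The source may report more compounds than this note shows. Statements on the series, on what has been measured and on what is new or still open speak of the compounds shown alone.

Compound 2 `CCSc1ccc(C2C(Oc3ccccc3)C(=O)N2c2cc(OC)c(OC)c(OC)c2)cc1` gives 632 nM in a functional assay on HT-29 cells (Homo sapiens) for inhibition, read by sulforhodamine B assay, with a stated time of 72 h (on this read-out lower numbers stand for stronger inhibition and higher numbers for weaker inhibition), the highest of the three numbers recorded. Compound 1 `CCSc1ccc(C2CC(=O)N2c2cc(OC)c(OC)c(OC)c2)cc1` gives 311 nM and compound 3 `C=CC1C(=O)N(c2cc(OC)c(OC)c(OC)c2)C1c1ccc(SCC)cc1` gives 257 nM in this assay. The measured steps are a 2.0-fold higher number from compound 1 to compound 2 (0.31 log units; beyond the scatter), a 2.5-fold lower number from compound 2 to compound 3 (0.39 log units; beyond the scatter) and a 1.2-fold lower number from compound 1 to compound 3 (0.08 log units; within the scatter); each of them concerns the saturated ring carbon only.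

Compound 4 `COc1cc(N2C(=O)C(Oc3ccccc3)C2c2ccc(SC)cc2)cc(OC)c1OC` differs from compound 2 by hydrogen in place of methyl on a saturated chain carbon bound to a sulfur. Within the data shown here, no measured step touches the ethylsulfanyl group, so nothing in this set speaks for a change beyond the scatter, and the expectation for compound 4 is accordingly a 1.1-fold lower number from compound 2 to compound 4 (0.02 log units; within the scatter). Compound 4 is therefore estimated at 600 nM in this assay, with a range from 300 nM to 1300 nM.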

Compound 4, half-maximal inhibitory concentration: 336 nM
Compound 4: the middle estimate sits 1.8-fold (0.25 log units) above what was measured; low and high end bracket the measured number.
By their numbers in this assay, from the lowest: compounds 3, 1, 4 and 2 (each within the scatter of the next, the first and the last beyond it).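

Among these compounds, this is the first measured change at the ethylsulfanyl group, and with the phenoxy group held fixed, methylsulfanyl in its place gives a 1.9-fold lower number from compound 2 to compound 4 (0.27 log units; within the scatter) in this assay. Removing this methyl therefore moves the number no further than repeated measurements would, so this position shows no clear sensitivity to this change. Nothing at hand bears on the cause of this result. On these data alone, whether the same change behaves alike in compound 1 or compound 3 stays open. So does the effect of a longer chain such as propyl, or of an amine on that chain.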